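Adding a Second Methyl to Compound 2

The source may report more compounds than this note shows. Statements on the series, on what has been measured and on what is new or still open speak of the compounds shown alone.

Of the compounds shown here, two with the shared core have been measured so far. In a functional assay on SF-295 cells (Homo sapiens) for antiproliferative activity (on this read-out higher numbers stand for weaker inhibition of growth and lower numbers for stronger inhibition of growth), compound 1 `Cc1ccnc2nc(-c3ccc4ccccc4c3)cc(O)c12` gives 1480 nM and compound 2 `Cc1ccc2c(O)cc(-c3ccc4ccccc4c3)nc2n1` gives 3800 nM. Compound 2 therefore has the higher number of the two, meaning weaker inhibition of growth, and the gap lies beyond the usual scatter. Compound 3 `Cc1cc(C)c2c(O)cc(-c3ccc4ccccc4c3)nc2n1` follows from compound 2 by methyl in place of hydrogen on an aromatic carbon, opposite the ring nitrogen. Among the measured compounds shown here, no measured pair shows this change alone. Compound 1, however, carries a methyl at that same place and gives 1480 nM, so a small move toward stronger inhibition seems likely. In this assay the expected step is a 1.9-fold lower number from compound 2 to compound 3 (0.28 log units; within the scatter), a size hard to tell from the scatter. For compound 3 the estimated value is 2000 nM, with an expected range from 600 nM to 6000 nM.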

Compound 3, concentration for 50% growth inhibition: 14800 nM
Beside the measured number, compound 3's estimate is 7.4-fold (0.87 log units) below it; the whole stated range lies below it.
By their numbers in this assay, from the lowest: compound 1; then compound 2; then compound 3.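

In this assay, the first pair differing only at this position shows that methyl in place of hydrogen, opposite the ring nitrogen, gives weaker inhibition of growth, with a 3.9-fold higher number from compound 2 to compound 3 (0.59 log units; beyond the scatter). Compound 3 can also be reached by adding a methyl to compound 1 at the other ring carbon, and that change gives a 10-fold higher number from compound 1 to compound 3 (1.00 log units; beyond the scatter). Compound 3, with both methyl groups, therefore inhibits growth less strongly than either compound with a single methyl, so a methyl already present at this position in compound 1 did not predict the effect of adding one to compound 2.

From the compounds shown here alone, whether an ethyl chain, a methoxy group or an amine at this position would also weaken inhibition remains open. No measurement here explains why the second methyl has this effect.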